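The source may hold more compounds than are shown below. What is called first, only, known or untested is meant among the compounds shown, and "the series" means these compounds.

For the measured compounds named here, compound 1 `O=C(/C=C/c1ccccc1)c1nc2ccccc2[nH]1` stands lowest of the three numbers so far in a functional assay on HCT-116 cells (Homo sapiens) for antiproliferative activity, read by MTT assay, with a stated time of 48 h (on this read-out higher numbers stand for weaker inhibition and lower numbers for stronger inhibition), giving 200 nM. Compound 3 `O=C(/C=C/c1cccc(Br)c1)c1nc2ccccc2[nH]1` gives 790 nM and compound 2 `O=C(/C=C/c1cccnc1)c1nc2ccccc2[nH]1` gives 15300 nM; the corresponding steps are a 4.0-fold higher number from compound 1 to compound 3 (0.60 log units; beyond the scatter) and a 77-fold higher number from compound 1 to compound 2 (1.88 log units; beyond the scatter). Compound 4 `O=C(/C=C/c1ccc(Br)cc1)c1nc2ccccc2[nH]1` differs from compound 1 by bromo in place of hydrogen on an aromatic carbon. Going by the values given here, the only measured step that bears on this change is a 4.0-fold higher number from compound 1 to compound 3 (0.60 log units; beyond the scatter), the same bromo in place of hydrogen on an aromatic carbon at a different place on the ring; the step to compound 2 is of another kind and does not bear on it. A modest rise in this assay is therefore expected. For compound 4 the estimate is 600 nM, within 200 nM to 2000 nM, an expected step of a 3.0-fold higher number from compound 1 to compound 4 (0.48 log units; beyond the scatter).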

Compound 4, half-maximal inhibitory concentration: 19600 nM
Compound 4: the middle estimate sits 33-fold (1.51 log units) below what was measured; the measured number lies above the stated range.
By their numbers in this assay, from the lowest: compound 1; then compound 3; then compounds 2 and 4 (each within the scatter of the next).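

In this assay, bromo para to a large group gives a far larger step (a 98-fold higher number from compound 1 to compound 4 (1.99 log units; beyond the scatter)) than bromo elsewhere on the ring (a 4.0-fold higher number from compound 1 to compound 3 (0.60 log units; beyond the scatter)). The same replacement thus does not carry a single size of step across this ring: its size depends on where the bromo sits, at least across these two compounds. Nothing measured on hand accounts for this difference. As far as these compounds go, whether a fluoro or methoxy group at this place gives a step of similar size remains open, as does whether an amine is tolerated there.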